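The source may hold more compounds than are shown below. What is called first, only, known or untested is meant among the compounds shown, and "the series" means these compounds.

Compound 1: `CC(=O)OCC[C@@H]1C[C@@H](c2ccc(F)c(F)c2)[C@H](NC(=O)c2cc(-c3c(Cl)cnn3C)c(Cl)o2)CN1`, 3.4 nM 
Compound 2: `Cn1ncc(Cl)c1-c1cc(C(=O)NC2CNCC2c2ccc(C(F)(F)F)cc2)oc1Cl`, 538 nM 
Compound 3: `Cn1ncc(Cl)c1-c1cc(C(=O)N[C@@H]2CN[C@H](CC(=O)NCC(O)CO)C[C@H]2c2ccc(Cl)c(Cl)c2)oc1Cl`, 3.13 nM 

In an assay for inhibition of RAC-alpha serine/threonine-protein kinase (Homo sapiens), read by HTRF, with a stated time of 1 h (a lower number here means a stronger inhibitor, a higher number a weaker inhibitor), compound 3 gives 3.13 nM, the lowest of the three numbers in hand. Its nearest neighbour on the scale is compound 1, whose 3.4 nM lies within the scatter of compound 3, so no order can be read between those two. Among the compounds with values here, compound 2, at 538 nM, sits far higher than compound 3, a gap well beyond the scatter; no single-change step connects compound 2 to either of the others, so only the two numbers themselves can be compared.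

Compound 4, `Cn1ncc(Cl)c1-c1cc(C(=O)N[C@@H]2CN[C@H](CCCO)C[C@H]2c2ccc(Cl)c(Cl)c2)oc1Cl`, has not yet been measured in this assay. It differs from compound 3 in one place: 2-hydroxyethyl in place of (2,3-dihydroxypropyl)carbamoyl on a saturated chain carbon bound to a saturated ring carbon. The side chain of compound 4 is thus shortened to 3-hydroxypropyl, a chain not unlike the acetoxyethyl chain that compound 1 carries on its own core while giving 3.4 nM.

Within the data shown here, with no measured single-change step to rest on, the step from compound 3 to compound 4 is expected to be small, a 1.4-fold higher number from compound 3 to compound 4 (0.16 log units; within the scatter), with no clear direction beyond the scatter. Compound 4 is estimated to give 4.5 nM in this assay, within a range from 1.5 nM to 14 nM.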

Compound 4, half-maximal inhibitory concentration: 2.56 nM
Beside the measured number, compound 4's estimate is 1.8-fold (0.24 log units) above it; the measured number falls inside the stated range.
By their numbers in this assay, from the lowest: compounds 4, 3 and 1 (each within the scatter of the next); then compound 2.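

Within the data shown here, the step gives the first single-change reading at this position: in this assay, 2-hydroxyethyl in place of (2,3-dihydroxypropyl)carbamoyl on a saturated chain carbon bound to a saturated ring carbon gives a 1.2-fold lower number from compound 3 to compound 4 (0.09 log units; within the scatter). The group that leaves has 8 heavy atoms, 3 hydrogen-bond donors and 3 hydrogen-bond acceptors, and the group that enters has 3 heavy atoms, 1 hydrogen-bond donor and 1 hydrogen-bond acceptor, so for this pair the carbamoyl and the larger part of the chain can go with no change that reads beyond the scatter. No measurement is available to explain why the two numbers stay together.

The compounds shown leave open whether the remaining hydroxyl matters at all: a plain propyl chain, an amine or a carboxylic acid at the end of the chain could each read differently, and a single pair cannot say. Among these compounds, they also leave open whether the same change would read alike on a compound with the aryl group of compound 1 in place of the one shared by compound 3 and compound 4.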